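Swapping benzoyloxy for a triazole on a non-toxic scaffold

The source may hold more compounds than are shown below. What is called first, only, known or untested is meant among the compounds shown, and "the series" means these compounds.

Of the compounds shown here, three have been tested in an ADME assay on L02 cells (Homo sapiens) for cytotoxicity, read by MTT assay, with a stated time of 48 h; a lower number here means a stronger inhibitor, a higher number a weaker inhibitor. Compound 1 `O=C1O[C@@H](CN2CCC(O)CC2)CN1c1ccc(-n2cc(-c3ccccn3)cn2)c(F)c1` gives > 400 ug/mL, which is a limit of the assay and not a number. Compound 2 `CC(=O)OC[C@H]1CN(c2ccc(-n3cc(-c4ccccn4)cn3)c(F)c2)C(=O)O1` likewise gives > 400 ug/mL, again a limit. Compound 3 `O=C(OC[C@H]1CN(c2ccc(-n3cc(-c4ccccn4)cn3)c(F)c2)C(=O)O1)c1ccccc1` gives > 400 ug/mL, also a limit. Because all three sit at the limit of > 400 ug/mL in this assay, at which 3 of the 3 values shown sit, the steps among them cannot be read: a step that the two limits leave unreadable from compound 1 to compound 2, a step that the two limits leave unreadable from compound 1 to compound 3 and a step that the two limits leave unreadable from compound 2 to compound 3. Compound 3 therefore stands at the same limit as the other two.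

Compound 4 `O=C1O[C@@H](Cn2ccnn2)CN1c1ccc(-n2cc(-c3ccccn3)cn2)c(F)c1` differs from compound 3 in one place: 1H-1,2,3-triazol-1-yl in place of benzoyloxy on a saturated chain carbon bound to a saturated ring carbon. Going by the values given here, the measured steps carry no readable size, so they give no direction for this change; they show only that three different groups at this place all leave the cells equally untouched within the concentrations tested. The expected step that the limit leaves unreadable from compound 3 to compound 4 is therefore none beyond the scatter. Compound 4 is estimated at 600 ug/mL, between 300 ug/mL and 2000 ug/mL, and is most likely to be reported once more as a limit.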

Compound 4, half-maximal inhibitory concentration: 49 ug/mL
Compound 4: middle estimate off by 12-fold (1.09 log units), on the high side, outside the stated range (below it).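

In this assay, going by these compounds alone, this place, on a saturated chain carbon bound to a saturated ring carbon, turns out to matter: with 1H-1,2,3-triazol-1-yl there, compound 4 gives a value that can be read as a number, unlike the earlier compounds. The change is an at least 8.1-fold lower number from compound 3 to compound 4 (0.91 log units; beyond the scatter), an at least 8.1-fold lower number from compound 2 to compound 4 (0.91 log units; beyond the scatter) and an at least 8.1-fold lower number from compound 1 to compound 4 (0.91 log units; beyond the scatter), and each size is only a minimum because the other end of every step is a limit: the limit of > 400 ug/mL in this assay, at which 3 of the 4 values shown sit. The steps among compound 1, compound 2 and compound 3 still cannot be read, so the three earlier groups cannot be ranked against each other.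

On these data alone, what remains open is whether this effect belongs to the 1H-1,2,3-triazol-1-yl group alone or to five-membered nitrogen rings more widely. A 1H-1,2,4-triazol-1-yl or 1H-imidazol-1-yl group at the same place would help separate the two.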